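The compounds below may be only part of what the source reports. "The series", "measured", "known", "first", "only" and "open" are said of these compounds alone.

Compound 2 `Cc1cc(C(N)=O)nn1Cc1cc(Cl)ccc1OCC(C)C` shares its core with compound 1 `Cc1cc(C(N)=O)nn1Cc1cc(Cl)ccc1OCc1ccccc1` and compound 3 `Cc1cc(NC(=O)OCC(C)C)nn1Cc1cc(Cl)ccc1OCc1ccccc1`, differing from compound 1 only in the chain on the ether oxygen. In an assay on CHO-K1 cells for displacement of a labelled ligand from prostaglandin E2 receptor EP1 subtype (Homo sapiens) (a higher number here means a weaker inhibitor, a lower number a stronger inhibitor), compound 2 gives 126 nM, and compound 1 gives 126 nM in this assay, so between them there is no change at the digits printed from compound 1 to compound 2 (within the scatter); together these two sit at the high end of the three numbers. Compound 3 gives 25.1 nM in this assay, and the step of a 5.0-fold lower number from compound 1 to compound 3 (0.70 log units; beyond the scatter) is the only one in this set that moves the number beyond the scatter.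

Compound 4 `Cc1cc(NC(=O)OC(C)(C)C)nn1Cc1cc(Cl)ccc1OCC(C)C` is the not yet measured analogue of compound 2, with (tert-butoxycarbonyl)amino in place of carbamoyl on an aromatic carbon. Going by the values given here, the change closely resembles the one from compound 1 to compound 3, which is the step that bears on it, while the step from compound 1 to compound 2 suggests the chain on the ether oxygen matters little here. For compound 4 an improvement of about a 4.2-fold lower number from compound 2 to compound 4 (0.62 log units; beyond the scatter) in this assay is therefore expected. Compound 4 is estimated at 30 nM, within a range from 12 nM to 75 nM.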

Compound 4, half-maximal inhibitory concentration: 31.6 nM
The estimate for compound 4 lay 1.1-fold (0.02 log units) below the measured number; the measured number falls inside the stated range.
By their numbers in this assay, from the lowest: compounds 3 and 4 (each within the scatter of the next); then compounds 1 and 2 (each within the scatter of the next).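

In this assay, (tert-butoxycarbonyl)amino in place of carbamoyl on the aromatic carbon gives a 4.0-fold lower number from compound 2 to compound 4 (0.60 log units; beyond the scatter). Until now, the only such gain at this carbon was a 5.0-fold lower number from compound 1 to compound 3 (0.70 log units; beyond the scatter), which came with the (isobutoxycarbonyl)amino group and the ether chain of compound 1; the new step shows a similar replacement also lowering the number beyond the scatter with the different ether chain of compound 2. No measurement shown accounts for this gain.

Compounds 3 and 4 differ in two places, so the compounds shown cannot separate the contribution of the isobutyl and tert-butyl parts from that of the ether chain. On these data alone, it also remains open how a plain amine or a carboxylic acid on this aromatic carbon would compare with carbamoyl.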